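Amide cap variation: from compound 3 toward compound 4

A few compounds are considered here, and "the series" means these few. Any claim that something is new, unique, unknown or untested is made for them only; others in the source may bear on it.

Working notes on the amide cap of this series, followed in an assay on HEK293 cells for negative allosteric modulation of metabotropic glutamate receptor 5 (Homo sapiens), read by FLIPR, with a stated time of 1 h; on this read-out higher numbers stand for weaker inhibition and lower numbers for stronger inhibition.

Compound 1 `COc1ccccc1C#Cc1nc2c(s1)C(=O)NCC2` returns no number in this assay but only a limit, > 10000 nM, the point described by the limit of > 10000 nM in this assay, at which 1 of the 3 values shown sits. Compound 2 `O=C1c2sc(C#Cc3ccccc3)nc2CN1C1CC1` gives 23 nM in this assay. Compound 3 `O=C(C1CCC1)N1CCc2nc(C#Cc3ccccc3)sc2C1` gives 370 nM in this assay, the higher of the two numbers shown; the nearest comparator is compound 2, whose number lies lower by a margin beyond the usual scatter.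

Compound 4 `Cc1cccc(C(=O)N2CCc3nc(C#Cc4ccccc4)sc3C2)n1` has not yet been measured in this assay. It differs from compound 3 in one place: 6-methylpyridin-2-yl in place of cyclobutyl on a carbonyl carbon. For the measured compounds named here, no comparable pair among the measured compounds exists, so the size of this step can only be anticipated. A moderate move toward lower numbers is expected, a 2.5-fold lower number from compound 3 to compound 4 (0.39 log units; beyond the scatter), with considerable uncertainty in both directions. Compound 4 is therefore estimated at 150 nM in this assay, with a range from 30 nM to 800 nM.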

Compound 4, half-maximal inhibitory concentration: > 10000 nM
Compound 4: a limit, no number; the forecaster's own chance of this, stated with the estimate: 5%; at least 66-fold (1.82 log units) between middle value and limit.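

The amide cap now has its first one-place comparison: on a carbonyl carbon bonded to the ring amide nitrogen, 6-methylpyridin-2-yl in place of cyclobutyl gives an at least 27-fold higher number from compound 3 to compound 4 (1.43 log units; beyond the scatter) in this assay. This position is therefore not indifferent to the cap, since the cyclobutyl amide compound 3 keeps a measurable number and the aromatic cap does not. The result for compound 4 is a limit and not a number, so the step marks only a minimum, and this limit now recurs in the series: the limit of > 10000 nM in this assay, at which 2 of the 4 values shown sit.

Still open, from the compounds shown here alone, is whether the loss belongs to the aromatic ring, its ring nitrogen or its methyl group. Phenyl and unsubstituted pyridin-2-yl caps would separate these, while cyclopropyl or cyclopentyl caps would test how far the cyclobutyl result extends.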